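Rearranging the carbon chain on the sulfur of compound 1

The source may hold more compounds than are shown below. What is called first, only, known or untested is meant among the compounds shown, and "the series" means these compounds.

Three compounds sharing one core have been examined in an assay on isolated protein for inhibition of Retinaldehyde dehydrogenase 3 (Homo sapiens); a higher number here means a weaker inhibitor, a lower number a stronger inhibitor. Compound 1, with the structure `Cn1ncc2c(=O)n(-c3ccccc3)c(SC(C)(C)c3ccccc3)nc21`, carries a 1-methyl-1-phenylethyl group on its sulfur, and in this assay compound 1 gives 1390 nM. That is the highest of the three numbers seen so far. Compound 3, drawn as `CC(Sc1nc2c(cnn2C)c(=O)n1-c1ccc(CO)cc1)c1ccccc1`, sits nearest to it: in this assay compound 3 gives 1000 nM, a difference from compound 1 that falls within the scatter of repeated measurements. Compound 2, with the structure `Cn1ncc2c(=O)n(-c3ccccc3)c(SCc3cccc(F)c3)cc21`, lies furthest away, since in this assay compound 2 gives 140 nM, a gap from compound 1 that goes beyond the scatter.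

Compound 4, drawn as `CCC(Sc1nc2c(cnn2C)c(=O)n1-c1ccccc1)c1ccccc1`, has not yet been measured. It differs from compound 1 in one place only: 1-phenylpropyl in place of 1-methyl-1-phenylethyl on a sulfur. The two compounds contain the same atoms, joined differently. Going by the values given here, no measured pair shows exactly this kind of step, so the expectation rests on the closeness of compound 1 and compound 3, which carry two different branched chains on the sulfur and still give numbers within the scatter of each other. The step from compound 1 to compound 4 is therefore expected to be small, a 1.5-fold lower number from compound 1 to compound 4 (0.17 log units; within the scatter), with no clear direction beyond the scatter. On that basis compound 4 is estimated to give 950 nM in this assay, within a range from 350 nM to 2600 nM.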

Compound 4, half-maximal inhibitory concentration: 119 nM
Beside the measured number, compound 4's estimate is 8.0-fold (0.90 log units) above it, and the stated range ends above it.
By their numbers in this assay, from the lowest: compounds 4 and 2 (each within the scatter of the next); then compounds 3 and 1 (each within the scatter of the next).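

In this assay the group on the sulfur turns out to be sensitive to how its carbons are joined. Replacing 1-methyl-1-phenylethyl with 1-phenylpropyl gives a 12-fold lower number from compound 1 to compound 4 (1.07 log units; beyond the scatter) even though the two groups match in heavy-atom count, carry the same aromatic ring and have no hydrogen-bond donors or acceptors, so these counted features alone do not settle the number at this position. Nothing available explains why this rearrangement matters so much.

The compounds shown leave open how far this position tolerates further change, for instance whether a longer chain such as 1-phenylbutyl would keep the number of compound 4 or lose it. They also leave open whether an amine or a carboxylic acid at the end of the propyl chain would be accepted on the sulfur of the shared core, and whether the step seen here would hold with a different group in place of the phenyl ring of the 1-phenylpropyl group.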